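Compound 3 Expected Close to Compound 2

The source may hold more compounds than are shown below. What is called first, only, known or untested is meant among the compounds shown, and "the series" means these compounds.

Measured compounds:
compound 1 `Cc1cc(F)c(S(C)(=O)=O)cc1C(=O)N=C(N)N` gives 44 nM
compound 2 `Cc1cc(Sc2ccncc2)c(S(C)(=O)=O)cc1C(=O)N=C(N)N` gives 13 nM

Going by the values given here, in a functional assay for inhibition of sodium/hydrogen exchanger (Oryctolagus cuniculus) (on this read-out higher numbers stand for weaker inhibition and lower numbers for stronger inhibition), compound 2 holds the lowest of the two numbers; the only measured step, a 3.4-fold lower number from compound 1 to compound 2 (0.53 log units; beyond the scatter), shows that putting a ring-bearing group in place of fluoro lowered the number. Compound 3 `Cc1cc(Nc2cccc(Cl)c2)c(S(C)(=O)=O)cc1C(=O)N=C(N)N` differs from compound 2 as follows: (3-chlorophenyl)amino in place of (pyridin-4-yl)sulfanyl on an aromatic carbon. One ring-bearing group is exchanged for another, so the change is of a kind the measured step does not directly cover. The number is expected to move little, a 1.2-fold higher number from compound 2 to compound 3 (0.06 log units; within the scatter). Compound 3 is therefore estimated at 15 nM, with a range from 5 nM to 50 nM.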

Compound 3, half-maximal inhibitory concentration: 33 nM
The estimate for compound 3 lay 2.2-fold (0.34 log units) below the measured number; low and high end bracket the measured number.
By their numbers in this assay, from the lowest: compound 2; then compounds 3 and 1 (each within the scatter of the next).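

The change of (pyridin-4-yl)sulfanyl to (3-chlorophenyl)amino gives a 2.5-fold higher number from compound 2 to compound 3 (0.40 log units; beyond the scatter) in this assay, so the two ring-bearing groups are not interchangeable at this position. The (3-chlorophenyl)amino group compared with fluoro gives a 1.3-fold lower number from compound 1 to compound 3 (0.12 log units; within the scatter) and so does not clearly separate from the small atom, which means that a ring here does not by itself give the lower number of compound 2. No measurement at hand accounts for this difference.

As far as these compounds go, compound 2 and compound 3 differ in both the linking atom and the ring, and how much each contributes stays open. A (pyridin-4-yl)amino group or a (3-chlorophenyl)sulfanyl group would separate the two.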